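A few compounds are considered here, and "the series" means these few. Any claim that something is new, unique, unknown or untested is made for them only; others in the source may bear on it.

Working notes on the series. Compound 1 `CNC(=O)/C=C/c1ccncc1-c1ccc2c(cnn2C)c1` carries a 2-(methylcarbamoyl)ethenyl group on the shared core. In an assay on a protein complex for inhibition of CDK8/Cyclin C (Homo sapiens), with a stated time of 1 h (a lower number here means a stronger inhibitor, a higher number a weaker inhibitor), compound 1 gives 86.7 nM. Compound 2 `O=C(O)COc1ccncc1-c1ccc2ccccc2c1` belongs to the same set; in this assay compound 2 has "not determined" (no result reported). Compound 3 `CN1CCN(c2ccc(Nc3cnccc3/C=C/C(N)=O)cc2)CC1` is the third member; in this assay compound 3 has "not determined" (no result reported). For the measured compounds named here, the half-maximal inhibitory concentration of compound 1 is therefore the only number available, and compound 1 is the sole reference point for the step considered here.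

Compound 4 `Cn1ncc2cc(-c3cnccc3/C=C/C(=O)O)ccc21` differs from compound 1 in a single place: hydroxy in place of methylamino on a carbonyl carbon. Put another way, the 2-(methylcarbamoyl)ethenyl of compound 1 becomes 2-carboxyethenyl in compound 4, the methylcarbamoyl turning into carboxy. Going by the values given here, no step between two measured compounds is available to calibrate this change, so the expectation rests on the value of compound 1 alone and on the nature of the change.

The step from compound 1 to compound 4 is expected to weaken inhibition in this assay beyond the scatter, the expected step being a 14-fold higher number from compound 1 to compound 4 (1.14 log units; beyond the scatter). Compound 4 is accordingly estimated at 1200 nM in this assay, with a range from 250 nM to 6000 nM.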

Compound 4, half-maximal inhibitory concentration: 34.6 nM
Beside the measured number, compound 4's estimate is 35-fold (1.54 log units) above it; the measured number lies below the stated range.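

The change of methylamino to hydroxy on a carbonyl carbon gives a 2.5-fold lower number from compound 1 to compound 4 (0.40 log units; beyond the scatter) in this assay, so methylamino is not required at this place for inhibition, and the carboxy group is compatible with a modestly stronger inhibitor. For the compounds shown here, a single value could not show this: the pair gives the first measured reading for this place on the shared core, showing that the number responds to a change here and that this particular change lowers it. No measurement available bears on why the step runs in this direction.

The compounds shown leave open how a methoxy or dimethylamino group on the same carbonyl carbon would compare with methylamino and hydroxy, and so whether the lower number follows hydroxy specifically or the removal of methylamino. They also leave open whether a longer chain in place of the ethenyl link would preserve the step, and whether the same exchange would give a step of similar size on a different core.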